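Working notes on a two-compound series and one new analogue

The compounds below may be only part of what the source reports. "The series", "measured", "known", "first", "only" and "open" are said of these compounds alone.

Measured so far:
Compound 1 `C=CCn1c(=S)n([C@@H]2O[C@H](CO)[C@H]3OC(C)(C)O[C@H]32)c2nc(N)nc(O)c21`: 89%
Compound 2 `COc1ccc(Cn2c(=O)n(C3OC(CO)[C@@H](O)[C@H]3O)c3nc(N)nc(O)c32)cc1`: 44%

In a functional assay on the whole organism (B cells) with Mus musculus as the target (on this read-out higher numbers stand for larger maximal responses and lower numbers for smaller maximal responses), compound 1 gives 89%. Compound 2 gives 44% in this assay, the lowest of the two numbers; its nearest neighbour is compound 1, whose number is higher by a margin beyond the scatter. The two measured compounds differ in more than one place, so no single step can be read between them; only the two values themselves stand for comparison.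

Compound 3 `Nc1nc(O)c2c(n1)n(C1OC(CO)[C@@H](O)[C@H]1O)c(=O)n2CC(O)CO` differs from compound 2 as follows: 1,2-dihydroxyethyl in place of 4-methoxyphenyl on a saturated chain carbon bound to an aromatic nitrogen. The measured pair gives no guidance on how such a change acts on this read-out, so the expected step of a number 6 percentage points higher from compound 2 to compound 3 (within the scatter) is small and without a clear direction, possibly none beyond the scatter. For compound 3 the estimated maximal response is 50%, expected to fall between 20% and 85%.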

Compound 3, largest response reached (reported as maximal response), in percent of the reference or control that the assay uses: 136%
Compound 3: the middle estimate sits 86 percentage points below what was measured; measured number outside the range, above it.
By their numbers in this assay, from the lowest: compound 2; then compound 1; then compound 3.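

Within this assay, 1,2-dihydroxyethyl in place of 4-methoxyphenyl on a saturated chain carbon bound to an aromatic nitrogen gives a number 92 percentage points higher from compound 2 to compound 3 (beyond the scatter), the only single-place step in the series so far. This position is therefore not silent on this read-out, and with the rest of compound 2 unchanged, the six-membered aromatic ring is not required there for a large maximal response. Nothing measured in the series accounts for the size of this step.

The step removes the aromatic ring and the methoxy group and brings in two hydroxyl groups at once, so the contribution of each remains unresolved. A plain propyl chain would test the chain without its hydroxyl groups, while a terminal amine or carboxylic acid would show whether other groups at the chain end give a similar response.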